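Lengthening the Acyl Chain of a Chloro Analogue

The source may hold more compounds than are shown below. What is called first, only, known or untested is meant among the compounds shown, and "the series" means these compounds.

Measured compounds:
Compound 1, `CCC(=O)NCCCCc1cccc(OC)c1`, gives 119 nM in an assay for binding affinity to melatonin receptor (Gallus gallus); a higher number here means a weaker inhibitor, a lower number a stronger inhibitor.
Compound 2, `CCCC(=O)NCCCCc1cccc(OC)c1`, gives 208 nM in this assay.
Compound 3, `CCCC(=O)NCCCc1cccc(Cl)c1`, gives 113 nM in this assay.

Compounds 1 and 2 share a core and differ by one change, (methyl in place of hydrogen on a saturated chain carbon, two bonds along the chain from a carbonyl carbon). That change made a step of a 1.7-fold higher number from compound 1 to compound 2 (0.24 log units; within the scatter), so within this pair the longer acyl chain moved the number only a little, and the two values cannot be set in any order.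

Compound 3 has a different core from compound 1; the difference between the two cores is not broken down here. Its value sits close to that of compound 1 and also within the usual spread of that of compound 2.

Compound 4, `CCCCC(=O)NCCCc1cccc(Cl)c1`, has not yet been measured. It differs from compound 3 by methyl in place of hydrogen on a saturated chain carbon, three bonds along the chain from a carbonyl carbon. For the measured compounds named here, this is the same kind of change as the one from compound 1 to compound 2, but not the same: there the methyl entered two bonds along the chain from the carbonyl carbon, here it enters three bonds along the chain from the carbonyl carbon. Because the earlier step was a 1.7-fold higher number from compound 1 to compound 2 (0.24 log units; within the scatter), the expected step from compound 3 to compound 4 is estimated as a 1.5-fold higher number from compound 3 to compound 4 (0.18 log units; within the scatter). Compound 4 is therefore expected to give about 170 nM in this assay, with a plausible range from 70 nM to 420 nM.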

Compound 4, inhibition constant: 15100 nM
Compound 4: the middle estimate sits 89-fold (1.95 log units) below what was measured; the measured number lies above the stated range.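

In this assay, placing a methyl in the position of a hydrogen on a saturated chain carbon, three bonds along the chain from a carbonyl carbon, turns a propyl into a butyl and gives a 130-fold higher number from compound 3 to compound 4 (2.13 log units; beyond the scatter), which is a large loss of binding for so small an addition. A change of this kind therefore cannot be carried from one core to another in this series with its size intact, since the two steps clearly disagree: the same change on two cores in this assay, a 1.7-fold higher number (0.24 log units; within the scatter) from compound 1 to compound 2 and a 130-fold higher number (2.13 log units; beyond the scatter) from compound 3 to compound 4, 76-fold (1.88 log units) apart, beyond the scatter of two such steps What this does not show is the source of the disagreement, since the two pairs differ both in their core and in where the methyl enters, two bonds along the chain from the carbonyl carbon in one and three bonds along in the other, and two steps alone cannot separate these or support a general rule.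

The compounds shown leave open whether the same propyl to butyl change on the core of compound 1 would also give a large step or a small one. They also leave open how binding on the core of compound 3 responds to a still longer chain or to a branched chain such as isopropyl in the same place.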